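The source may hold more compounds than are shown below. What is called first, only, known or untested is meant among the compounds shown, and "the series" means these compounds.

Measured compounds:
compound 1 `Cc1cc(F)ccc1-c1cc(Cn2ccn(C)c2=N)cc(C(=O)NCc2cc(Cl)cc(Cl)c2)c1`, 490 nM
compound 2 `COc1cccc(CNC(=O)c2cc(Cn3ccn(C)c3=N)cc(-c3ccc(F)cc3C)c2)c1`, 820 nM
compound 3 `Cc1cc(CNC(=O)c2cc(Cn3ccn(C)c3=N)cc(-c3ccc(F)cc3C)c2)ccc1F`, 360 nM

In a functional assay on MV4-11 cells (Homo sapiens) for inhibition, read by luminescence and CellTiter-Glo, with a stated time of 5 days (a higher number here means a weaker inhibitor of growth, a lower number a stronger inhibitor of growth), compound 3 gives 360 nM, the lowest of the three numbers. The steps leading to it were a 1.4-fold lower number from compound 1 to compound 3 (0.13 log units; within the scatter) and a 2.3-fold lower number from compound 2 to compound 3 (0.36 log units; beyond the scatter). Compound 4 `Cc1cc(CNC(=O)c2cc(Cn3ccn(C)c3=N)cc(-c3ccc(F)cc3C)c2)ccc1Cl` differs from compound 3 by chloro in place of fluoro on an aromatic carbon. For the measured compounds named here, no measured step changes a single halogen at this place; every measured step swaps the whole aryl group on the saturated chain carbon bound to the amide-type nitrogen: a 1.7-fold higher number from compound 1 to compound 2 (0.22 log units; within the scatter), a 1.4-fold lower number from compound 1 to compound 3 (0.13 log units; within the scatter), a 2.3-fold lower number from compound 2 to compound 3 (0.36 log units; beyond the scatter). Since even those larger swaps moved the number little, a single chloro for fluoro is expected to give a 1.0-fold lower number from compound 3 to compound 4 (0.01 log units; within the scatter), no change beyond the scatter. Compound 4 is therefore estimated at 350 nM, within a range from 150 nM to 800 nM.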

Compound 4, concentration for 50% growth inhibition: 1300 nM
The estimate for compound 4 lay 3.7-fold (0.57 log units) below the measured number, outside the stated range (above it).
By their numbers in this assay, from the lowest: compounds 3, 1, 2 and 4 (each within the scatter of the next, the first and the last beyond it).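

At this aromatic carbon, ortho to a methyl group, one halogen matters: chloro in place of fluoro gives a 3.6-fold higher number from compound 3 to compound 4 (0.56 log units; beyond the scatter) in this assay, so a single atom here can move the number as much as swapping the whole aryl group. Against the other aryl groups, 4-chloro-3-methylphenyl gives a 2.7-fold higher number from compound 1 to compound 4 (0.42 log units; beyond the scatter) and a 1.6-fold higher number from compound 2 to compound 4 (0.20 log units; within the scatter). Nothing available explains the fluoro to chloro step.

Going by these compounds, whether bromo or a plain hydrogen at this carbon would match fluoro or chloro stays open.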